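Toward compound 4: a methoxyphenyl on the triazole

This account rests on a few compounds, and the source may have more. Where it says the series, first, only, none or still open, it means among the compounds named here.

Measured compounds in a functional assay on A549 cells (Homo sapiens) for antiproliferative activity, read by MTT assay, with a stated time of 48 h; on this read-out lower numbers stand for stronger inhibition and higher numbers for weaker inhibition:
Compound 1 `C/C(=C\CC/C(C)=C/CC[C@@H]1[C@@]2(C)CCC(=O)C(C)(C)[C@H]2CC[C@@]1(C)O)CC/C=C(\C)C(=O)OCc1cn(-c2ccccc2Cl)nn1` gives a limit, > 150000 nM.
Compound 2 `C/C(=C\CC/C(C)=C/CC[C@@H]1[C@@]2(C)CCC(=O)C(C)(C)[C@H]2CC[C@@]1(C)O)CC/C=C(\C)C(=O)OCc1cn(-c2cccc(O)c2)nn1` gives 42800 nM.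
Compound 3 `C/C(=C\CC/C(C)=C/CC[C@@H]1[C@@]2(C)CCC(=O)C(C)(C)[C@H]2CC[C@@]1(C)O)CC/C=C(\C)C(=O)OCc1cn(-c2ccccc2C)nn1` gives a limit, > 150000 nM.

Compound 3 stands only at a limit of this assay, not at a number, and compound 1 shares that position (the limit of > 150000 nM in this assay, at which 2 of the 3 values shown sit). Among the measured compounds shown here, the one numbered value belongs to compound 2, which carries a 3-hydroxyphenyl on the aromatic nitrogen, and the step from it, an at least 3.5-fold higher number from compound 2 to compound 3 (0.54 log units; beyond the scatter), is read only as a bound. The step of an at least 3.5-fold lower number from compound 1 to compound 2 (0.54 log units; beyond the scatter) points the same way, while a step that the two limits leave unreadable from compound 1 to compound 3 cannot be read from two limits.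

Compound 4 `COc1ccc(-n2cc(COC(=O)/C(C)=C/CC/C(C)=C/CC/C(C)=C/CC[C@@H]3[C@@]4(C)CCC(=O)C(C)(C)[C@H]4CC[C@@]3(C)O)nn2)cc1` differs from compound 3 as follows: 4-methoxyphenyl in place of 2-methylphenyl on an aromatic nitrogen. For the measured compounds named here, no measured step covers a 4-methoxyphenyl, so the expectation rests on compound 2 and compound 3 alone. Compound 4 is expected to fall at 90000 nM, within 30000 nM to 200000 nM, meaning an expected step of an at least 1.6-fold lower number from compound 3 to compound 4 (0.22 log units; that floor lies within the scatter), with a fair chance that only a limit is reported again.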

Compound 4, half-maximal inhibitory concentration: > 150000 nM
Compound 4: a limit, no number; the forecaster's own chance of this, stated with the estimate: 50%; at least 1.6-fold (0.22 log units) between middle value and limit.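

In this assay, among the compounds shown here, compound 4 again gives a limit and not a number, so the 4-methoxyphenyl on the aromatic nitrogen joins the 2-chlorophenyl and the 2-methylphenyl at that limit: the limit of > 150000 nM in this assay, at which 3 of the 4 values shown sit. The one step that can be read is an at least 3.5-fold higher number from compound 2 to compound 4 (0.54 log units; beyond the scatter); the steps among compound 1, compound 3 and compound 4 cannot be read, as all three are limits. Among the four groups shown, the 3-hydroxyphenyl of compound 2 alone gives a number, and the loss of a number is no longer confined to the two 2-substituted phenyl groups.

As far as these compounds go, whether a 4-hydroxyphenyl or a 3-methoxyphenyl would also give a number stays open, and with it whether the hydroxyl or its place on the phenyl ring matters. From the compounds shown here alone, how an amine or a carboxylic acid on that phenyl ring would read also remains open.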